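The source may report more compounds than this note shows. Statements on the series, on what has been measured and on what is new or still open speak of the compounds shown alone.

Measured compounds:
compound 1, `CC1CCN(c2c(S(=O)(=O)c3ccc(Cl)cc3)cnc3cc(F)ccc23)CC1`: 90%
compound 2, `CC1CCN(c2c(S(=O)(=O)c3ccc(F)c(F)c3)cnc3cc(F)ccc23)CC1`: 94%

In an assay on isolated protein for displacement of a labelled ligand from metabotropic glutamate receptor 5 (Homo sapiens), with a stated time of 60 min, tested at 1 uM (a lower number here means less inhibition, a higher number more inhibition at the concentration tested (going by the name of the read-out)), compound 2 gives 94%. Against compound 1 it stands essentially level, since a number 4 percentage points higher from compound 1 to compound 2 (within the scatter). Compound 3 `CC1CCN(c2c(S(=O)(=O)c3ccccc3)cnc3cc(F)ccc23)CC1` differs from compound 2 in one place: phenyl in place of 3,4-difluorophenyl on a sulfonyl sulfur. Among the compounds with values here, the only measured step that bears on this change is the earlier exchange of one ring on the sulfonyl sulfur for another, which gave a number 4 percentage points higher from compound 1 to compound 2 (within the scatter). With just that to go by, the expectation for compound 3 in this assay is no step beyond the scatter, a number 6 percentage points lower from compound 2 to compound 3 (within the scatter). Compound 3 is therefore estimated at 88%, between 74% and 97%.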

Compound 3, a percentage reported as inhibition, at one concentration (the size of the read-out at that concentration, not a potency): 87%
Compound 3: middle estimate off by 1 percentage points, on the high side, and the stated range covers the measured number.
By their numbers in this assay, from the lowest: compounds 3, 1 and 2 (each within the scatter of the next).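

In this assay the ring on the sulfonyl sulfur needs no halogen to hold its reading: phenyl in place of 3,4-difluorophenyl leaves the result within the scatter (a number 7 percentage points lower from compound 2 to compound 3 (within the scatter)), and so does hydrogen in place of chloro on an aromatic carbon (a number 3 percentage points lower from compound 1 to compound 3 (within the scatter)). Nothing given here offers an explanation for this.

Going by these compounds, it stays open whether an amine or a carboxylic acid on this ring would hold the reading as well. On these data alone, these single-concentration numbers are also not potencies, so any differences in potency among the three compounds remain unknown.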